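Urea-to-amide exchange on the pyrazole series, forecast for compound 4

The source may hold more compounds than are shown below. What is called first, only, known or untested is meant among the compounds shown, and "the series" means these compounds.

Measured in a functional assay on CAKI-1 cells (Homo sapiens) for inhibition, read by sulforhodamine B assay, with a stated time of 48 h, tested at 0.1 uM; on this read-out higher numbers stand for a weaker effect at the one concentration tested and lower numbers for a stronger effect:
compound 1 `O=C(Nc1cccc(-n2cc(-c3ccncc3)c(-c3cc(O)cc(Cl)c3)n2)c1)Nc1ccc(Cl)c(Cl)c1` gives 98%
compound 2 `COc1cc(Cl)cc(-c2nn(-c3cccc(NC(=O)Nc4cc(C(F)(F)F)cc(C(F)(F)F)c4)c3)cc2-c2ccncc2)c1` gives 95%
compound 3 `COc1cc(Cl)cc(-c2nn(-c3cccc(NC(=O)Nc4ccc(Cl)c(Cl)c4)c3)cc2-c2ccncc2)c1` gives 102%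

Among the compounds with values here, compound 3 sits within the scatter of both other compounds: the step of a number 4 percentage points higher from compound 1 to compound 3 (within the scatter) is the only single-point change with two measured ends, and it does not move the read-out beyond the scatter. Compound 2 and compound 3, which differ in the aryl group on the urea, likewise give numbers within the scatter of each other, so none of the three is distinguished at this concentration.

Compound 4 `COc1cc(Cl)cc(-c2nn(-c3cccc(NC(=O)c4cccc(C(F)(F)F)c4)c3)cc2-c2ccncc2)c1` is the untested member. It differs from compound 3 by 3-(trifluoromethyl)phenyl in place of (3,4-dichlorophenyl)amino on a carbonyl carbon. Within the data shown here, no measured step covers this change; the nearest comparison, compound 2 against compound 3, only shows that swapping the aryl on the urea nitrogen leaves the read-out flat. Among the measured compounds shown here, with no precedent for the loss of the urea nitrogen and the group it carries, the step of a number 5 percentage points lower from compound 3 to compound 4 (within the scatter) is expected to stay within the scatter. Compound 4 is therefore estimated at 97%, with a range of 85% to 106%.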

Compound 4, a percentage reported as activity, at one concentration (the size of the read-out at that concentration, not a potency): 94%
The estimate for compound 4 lay 3 percentage points above the measured number; the range from low to high includes it.
By their numbers in this assay, from the lowest: compounds 4, 2, 1 and 3 (each within the scatter of the next).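

In this assay, exchanging (3,4-dichlorophenyl)amino for 3-(trifluoromethyl)phenyl on the carbonyl carbon gives a number 8 percentage points lower from compound 3 to compound 4 (within the scatter). Within the data shown here, the urea nitrogen and its hydrogen can therefore leave this position, turning the urea into an amide, without a shift beyond the scatter at this one concentration; the earlier compounds all kept the urea intact and could not show this. No measured property of these groups accompanies the result, so the data offer no account of it.

The compounds shown leave open whether any group on this carbonyl carbon moves the read-out beyond the scatter at this concentration. A piperidine amide, a carboxylic acid on the terminal ring, or a longer chain between the carbonyl and the ring would test how far this flat read-out extends.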